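Rearranging the heteroaromatic amide head of compound 1

The source may hold more compounds than are shown below. What is called first, only, known or untested is meant among the compounds shown, and "the series" means these compounds.

Measured compounds:
- compound 1 `O=C(NCc1ccc(S(=O)(=O)c2ccccc2)cc1)c1nc2cnccc2[nH]1`: 7100 nM
- compound 2 `O=C(Nc1ccc(S(=O)(=O)N2CCCCC2)cc1)c1cc2cnccc2[nH]1`: > 10000 nM
- compound 3 `O=C(NCc1ccc(S(=O)(=O)c2cccc(C(F)(F)F)c2)cc1)c1cc2ccncc2o1`: 5 nM

In an assay for inhibition of Nicotinamide phosphoribosyltransferase (Homo sapiens), read by mass spectrometry, with stated times of 15 min and 30 min (on this read-out lower numbers stand for stronger inhibition and higher numbers for weaker inhibition), compound 1 gives 7100 nM. Among the compounds for which a number was obtained, compound 1 has the highest number, so it is the weaker of the two. Its nearest measured neighbour is compound 3, which in this assay gives 5 nM, a far lower number and well beyond the scatter. Compound 2 does not reach a number at all: in this assay compound 2 gives > 10000 nM, which is a limit of the assay rather than a measured value (the limit of > 10000 nM in this assay, at which 1 of the 3 values shown sits).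

Compound 4 `O=C(NCc1ccc(S(=O)(=O)c2ccccc2)cc1)c1cnc2nccn2c1` has not yet been measured. It differs from compound 1 in one place, on the carbonyl carbon that carries the amide nitrogen: a group of 9 heavy atoms (6 carbon, 3 nitrogen; one five-membered aromatic ring with 2 hetero atoms, one six-membered aromatic ring with 2 hetero atoms) in place of a group of 9 heavy atoms (6 carbon, 3 nitrogen; one five-membered aromatic ring with 2 hetero atoms, one six-membered aromatic ring with 1 hetero atom), on a carbonyl carbon. The same atoms are present in both, joined differently, so that one hydrogen-bond donor is lost and a further acceptor appears in the bicyclic head.

No step between measured compounds with this particular change is available, so the expectation rests on the two numbers shown. Compound 1 starts weak, and compound 3 shows that this scaffold can reach very low numbers. For compound 4 a moderately lower number is expected, a step of a 24-fold lower number from compound 1 to compound 4 (1.37 log units; beyond the scatter). The estimate for compound 4 is 300 nM, with a range from 30 nM to 3000 nM.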

Compound 4, half-maximal inhibitory concentration: 2 nM
Compound 4: the middle estimate sits 150-fold (2.18 log units) above what was measured; measured number outside the range, below it.
By their numbers in this assay, from the lowest: compound 4; then compound 3; then compound 1. At a limit, above all of these: compound 2.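

With the rest of the molecule unchanged, replacing only the bicyclic group on the carbonyl carbon, using the same atoms joined differently, gives in this assay a 3600-fold lower number from compound 1 to compound 4 (3.55 log units; beyond the scatter) and shows that this single position can decide between a weak and a very strong inhibitor. The earlier compounds shown here differ from one another in more than one place, so none of their comparisons could isolate the contribution of this group. The group that enters has 0 hydrogen-bond donors, so compound 4 also shows that a low number in this assay does not require a donor in this group.

Nothing measured here explains why this change has so large an effect. Going by these compounds alone, the single pair cannot separate the loss of the donor from the gain of an acceptor or the new ring arrangement, and it leaves open how the same group would behave with a methyl group, an amine or a carboxylic acid attached to it.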